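Double-bond configuration: from compound 3 to compound 4

A few compounds are considered here, and "the series" means these few. Any claim that something is new, unique, unknown or untested is made for them only; others in the source may bear on it.

In an ADME assay on NIH3T3 cells (Mus musculus) for cytotoxicity, read by neutral red uptake, with a stated time of 48 h (on this read-out lower numbers stand for higher toxicity in this test and higher numbers for lower toxicity in this test), compound 1 `CCCCCCCC/C=C\c1c(C)c(/C=C\CCCCCCCC)c2[n+](c1C)CCC2` gives 22.7 uM, compound 2 `CCCCCCCC/C=C\c1c(C)c(/C=C/CCCCCCCC)c(C)[n+]2c1CCC2` gives 3.2 uM and compound 3 `CCCCCCCC/C=C/c1c(C)cc(C)[n+]2c1CCC2` gives 1.9 uM. Compound 3 thus sits within the scatter of compound 2 and well under compound 1 on these numbers.

The open case is compound 4 `CCCCCCCC/C=C\c1c(C)cc(C)[n+]2c1CCC2`, where the change is the two compounds have the same atoms and bonds and differ only in configuration as drawn: 1 of 1 stereo elements differ; a double bond is drawn E in compound 3 and Z in compound 4. For the measured compounds named here, one measured step bears on this: a 7.1-fold lower number from compound 1 to compound 2 (0.85 log units; beyond the scatter), which is traced to the fact that compounds 1 and 2 differ only in the configuration as drawn. Going by the values given here, there the number fell as a double bond went from Z to E. Since a 7.1-fold lower number from compound 1 to compound 2 (0.85 log units; beyond the scatter) is the only such comparison, and it comes from a different substitution of the shared core, the reverse change from E to Z is expected to raise the number in this assay, but by less. The expected change is a 2.6-fold higher number from compound 3 to compound 4 (0.42 log units; beyond the scatter), and the low end of the range allows for no real shift at all. For compound 4 the estimated value is 5 uM, with an expected range from 1.9 uM to 14 uM.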

Compound 4, half-maximal toxic concentration: 1.9 uM
Beside the measured number, compound 4's estimate is 2.6-fold (0.42 log units) above it; low and high end bracket the measured number.
By their numbers in this assay, from the lowest: compounds 3, 4 and 2 (each within the scatter of the next); then compound 1.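

In this assay, E and Z at this double bond give no change at the digits printed from compound 3 to compound 4 (within the scatter), so the configuration effect seen in a 7.1-fold lower number from compound 1 to compound 2 (0.85 log units; beyond the scatter) does not carry over to this compound with a single dec-1-en-1-yl group, and configuration is the only difference in this pair: the fact that compounds 3 and 4 differ only in the configuration as drawn

Hydrogen in place of the group of 10 heavy atoms gives a 1.7-fold lower number from compound 2 to compound 4 (0.23 log units; within the scatter), while hydrogen in place of dec-1-en-1-yl gives a 12-fold lower number from compound 1 to compound 4 (1.08 log units; beyond the scatter). For the compounds shown here, removing that group therefore makes a clear difference only when compound 1 is the starting point, and compound 1 remains the one compound set apart from the others.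

Going by these compounds, it remains open whether the double-bond configuration matters with a longer chain, such as tetradecenyl, or with a terminal amine or carboxylic acid on the chain. A saturated decyl chain in place of dec-1-en-1-yl is also untested among the compounds shown.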